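Replacing 4-fluorophenyl with fluoro in compound 2

The source may report more compounds than this note shows. Statements on the series, on what has been measured and on what is new or still open speak of the compounds shown alone.

Values measured so far in a physicochemical assay for acid dissociation, read by spectrophotometry

- compound 1 `CCOc1cc(CN2CCC(NC(=O)c3ccc(Cl)nc3)CC2)cc(OCC)c1-c1ccc(F)cc1` gives 7.8
- compound 2 `CCOc1cc(CN2CCC(NC(=O)c3cncc(C)c3)CC2)cc(OCC)c1-c1ccc(F)cc1` gives 7.69
- compound 3 `CCOc1cc(CN2CCC(NC(=O)c3cncc(C)c3)CC2)ccc1-c1ccc(F)cc1` gives 7.87

Compound 2 (7.69) stands within the scatter of compound 1 and of compound 3, so these numbers show no meaningful order. Compound 4 `CCOc1cc(CN2CCC(NC(=O)c3cncc(C)c3)CC2)cc(OCC)c1F` is the next to be read. It differs from compound 2 as follows fluoro in place of 4-fluorophenyl on an aromatic carbon with fluoro in place of 4-fluorophenyl on an aromatic carbon, ortho to two ethoxy groups and para to a large group.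

Among the measured compounds shown here, two measured steps bear on this change. With 5-methylpyridin-3-yl in place of 6-chloropyridin-3-yl on a carbonyl carbon the series shows a number 0.11 log units lower from compound 1 to compound 2 (within the scatter) and with hydrogen in place of ethoxy on an aromatic carbon it shows a number 0.18 log units higher from compound 2 to compound 3 (within the scatter) and neither step leaves the scatter. For the measured compounds named here, neither replaces the 4-fluorophenyl group, and every measured compound carries it, so the data hold no direct precedent. Going by the size of those two steps, no shift beyond the scatter is expected in this assay and a higher read-out is no more expected than a lower one. The estimated step is a number 0.01 log units higher from compound 2 to compound 4 (within the scatter) and nothing larger is expected.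

Compound 4 is estimated at 7.7 with an expected range from 7.4 to 8 in this assay for now.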

Compound 4, acid dissociation constant: 7.7
Estimate against measurement, compound 4: no gap at the digits printed; the measured number falls inside the stated range.
By their numbers in this assay, from the lowest: compounds 2, 4, 1 and 3 (each within the scatter of the next).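

In this assay, replacing 4-fluorophenyl with fluoro on this aromatic carbon, ortho to two ethoxy groups and para to a large group, gives a number 0.01 log units higher from compound 2 to compound 4 (within the scatter), so the two compounds cannot be told apart in this read-out. Among the compounds shown here, compound 4 is the first compound here without 4-fluorophenyl, which shows that a group of 7 heavy atoms with an aromatic ring can give way to a single fluorine with no step beyond the scatter, at least on this background of two ethoxy groups and 5-methylpyridin-3-yl on the carbonyl carbon. No supporting data are available that would account for this result at the position.

The compounds shown carry only 4-fluorophenyl or fluoro on this carbon, so the read-out with an amine, a carboxylic acid or a longer chain such as butoxy at the same place remains open. Also open, as far as these compounds go, is whether the fluoro replacement reads the same with 6-chloropyridin-3-yl on the carbonyl carbon, or with hydrogen in place of one ethoxy group.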